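A Chloro Group on the Anilino Ring of Compound 3

The source may report more compounds than this note shows. Statements on the series, on what has been measured and on what is new or still open speak of the compounds shown alone.

Compound 3 `O=C(Nc1ccc(Nc2nccc(Nc3ccccc3)n2)cc1)Nc1ccc(Cl)c(C(F)(F)F)c1` carries an anilino group on the shared core; in a functional assay on A549 cells (Homo sapiens) for antiproliferative activity, read by MTT assay, with a stated time of 72 h (on this read-out lower numbers stand for stronger inhibition and higher numbers for weaker inhibition), compound 3 reaches only the assay limit, > 50000 nM. That limit is the limit of > 50000 nM in this assay, at which 1 of the 3 values shown sits. Two close relatives give numbers: compound 1 `O=C(Nc1ccc(Nc2nccc(NC3CCCCC3)n2)cc1)Nc1ccc(Cl)c(C(F)(F)F)c1` gives 7430 nM and compound 2 `O=C(Nc1ccc(Nc2nccc(NC3CCCC3)n2)cc1)Nc1ccc(Cl)c(C(F)(F)F)c1` gives 5880 nM in this assay. The step of an at least 6.7-fold higher number from compound 1 to compound 3 (0.82 log units; beyond the scatter) and the step of an at least 8.5-fold higher number from compound 2 to compound 3 (0.92 log units; beyond the scatter) both run toward weaker inhibition, while a 1.3-fold lower number from compound 1 to compound 2 (0.10 log units; within the scatter) is within the scatter. Compound 4 `O=C(Nc1ccc(Nc2nccc(Nc3ccc(Cl)cc3)n2)cc1)Nc1ccc(Cl)c(C(F)(F)F)c1` differs from compound 3 by chloro in place of hydrogen on an aromatic carbon. Among the compounds with values here, no measured step exchanges hydrogen for chloro on this ring, so none bears directly on it. Since compound 3 gives only a limit, compound 4 is expected to stay near that limit, a change of about an at least 1.1-fold lower number from compound 3 to compound 4 (0.04 log units; that floor lies within the scatter). The estimate for compound 4 in this assay is 45000 nM, between 15000 nM and 100000 nM.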

Compound 4, half-maximal inhibitory concentration: 6320 nM
For compound 4 the middle estimate is 7.1-fold (0.85 log units) above the measured one, and the stated range ends above it.
By their numbers in this assay, from the lowest: compounds 2, 4 and 1 (each within the scatter of the next). At a limit, above all of these: compound 3.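

On the anilino ring, para to a large group, chloro in place of hydrogen gives an at least 7.9-fold lower number from compound 3 to compound 4 (0.89 log units; beyond the scatter) in this assay. That size is only a floor, since compound 3 gives a limit and not a number: the limit of > 50000 nM in this assay, at which 1 of the 4 values shown sits. The 4-chlorophenyl group also sits level with cyclopentyl and cyclohexyl, with a 1.1-fold higher number from compound 2 to compound 4 (0.03 log units; within the scatter) and a 1.2-fold lower number from compound 1 to compound 4 (0.07 log units; within the scatter), so an aromatic ring on this nitrogen does not by itself mean a limit value.

The compounds shown leave open whether fluoro, methoxy or an amine at this place would match chloro, and whether chloro elsewhere on this ring would do the same.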